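A few compounds are considered here, and "the series" means these few. Any claim that something is new, unique, unknown or untested is made for them only; others in the source may bear on it.

Among the measured compounds shown here, compound 2, with the structure `C=CC(=O)Nc1cccc(NC(=O)CSc2nc(Nc3ccccc3F)c3ccccc3n2)c1`, sits at the higher of the two numbers measured so far in a functional assay on PC-3 cells (Homo sapiens) for inhibition, read by MTT assay, with a stated time of 72 h (a lower number here means a stronger inhibitor, a higher number a weaker inhibitor), where compound 2 gives 9340 nM. Its nearest neighbour is compound 1, with the structure `C=CC(=O)Nc1cccc(NC(=O)CSc2nc(Nc3ccccc3)c3ccccc3n2)c1`, and in this assay compound 1 gives 8740 nM; the two differ by a 1.1-fold higher number from compound 1 to compound 2 (0.03 log units; within the scatter), so they cannot be told apart.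

Compound 3, with the structure `C=CC(=O)Nc1cccc(NC(=O)CSc2nc(Nc3ccccc3Cl)c3ccccc3n2)c1`, has not yet been measured. It differs from compound 2 in one place: chloro in place of fluoro on an aromatic carbon.

For the measured compounds named here, no measured step swaps chloro for fluoro, so nothing bears on this change directly. Going by the values given here, the only step available, a 1.1-fold higher number from compound 1 to compound 2 (0.03 log units; within the scatter), shows that the same position accepted a fluoro in place of hydrogen without a shift beyond the scatter. On that basis, the step from compound 2 to compound 3 is expected to be small, with no clear direction, and is estimated at a 1.0-fold higher number from compound 2 to compound 3 (0.01 log units; within the scatter). Compound 3 is therefore expected to give about 9500 nM in this assay, within a range from 4500 nM to 20000 nM.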

Compound 3, half-maximal inhibitory concentration: 14400 nM
The estimate for compound 3 lay 1.5-fold (0.18 log units) below the measured number; the measured number falls inside the stated range.
By their numbers in this assay, from the lowest: compounds 1, 2 and 3 (each within the scatter of the next).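

Replacing the fluoro with a chloro on this aromatic carbon, ortho to a large group, gives a 1.5-fold higher number from compound 2 to compound 3 (0.19 log units; within the scatter) in this assay, so a second halogen is now accepted here without a step beyond the scatter. Measured against the hydrogen at the same place, the chloro gives a 1.6-fold higher number from compound 1 to compound 3 (0.22 log units; within the scatter), which means that the compounds carrying hydrogen, fluoro and chloro here cannot be told apart and that the earlier reading of this position now rests on two replacements rather than one. No separate measurement is available to explain these numbers, so they describe what happens at this position but give no reason for it.

As far as these compounds go, the groups compared here are each a single atom, so it remains open whether a methoxy group, an amine or a carboxylic acid at this place would produce a step beyond the scatter. From the compounds shown here alone, it is also open whether a chloro or fluoro on another carbon of the same ring would behave as these two do.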